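A few compounds are considered here, and "the series" means these few. Any claim that something is new, unique, unknown or untested is made for them only; others in the source may bear on it.

Compound 1 `COC(=O)C1=C(C)N(c2ccccc2)C=C(C)C1c1ccccc1` and compound 2 `COC(=O)C1=C(C)N(c2cccc(Cl)c2)C=C(C)C1c1ccccc1` share one core, while compound 3 `CC1=C(C(=O)OC(C)(C)C)C(c2ccccc2)C=CN1c1ccccc1` and compound 4 `CC1=C(C(=O)OC(C)(C)C)C(c2ccccc2)C=CN1c1ccc(Cl)cc1` share another; the difference between the two cores is not broken down here. In a functional assay for inhibition, using microsomes, tested at 200 ug/mL (on this read-out lower numbers stand for a stronger effect and higher numbers for a weaker effect at the one concentration tested), compound 1 gives -37.4% and compound 2 gives -22.8%, so that a number 14.6 percentage points higher from compound 1 to compound 2 (beyond the scatter) follows from chloro in place of hydrogen on an aromatic carbon, placed meta to a large group. Compound 3 gives -42.1% in this assay. The change to compound 4 is chloro in place of hydrogen on an aromatic carbon, placed para to a large group, the same kind of change as before. For compound 4 a step of a number 12.1 percentage points higher from compound 3 to compound 4 (beyond the scatter) is expected in this assay, resting on the modest weakening seen in a number 14.6 percentage points higher from compound 1 to compound 2 (beyond the scatter). Compound 4 is therefore estimated at -30%, between -45% and -15%.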

Compound 4, a percentage reported as activity, at one concentration (the size of the read-out at that concentration, not a potency): -26.6%
Compound 4: middle estimate off by 3.4 percentage points, on the low side; the measured number falls inside the stated range.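

In this assay, chloro in place of hydrogen gives a number 15.5 percentage points higher from compound 3 to compound 4 (beyond the scatter). Set beside the earlier step, the size of the change carried over from one core to the other: the same change on two cores in this assay, a number 14.6 percentage points higher (beyond the scatter) from compound 1 to compound 2 and a number 15.5 percentage points higher (beyond the scatter) from compound 3 to compound 4, 0.9 percentage points apart, within the scatter of two such steps This rests on only two pairs, and the chloro sits para to a large group in compound 4 but at a different ring place in compound 2, so it does not show that the step would hold at every ring place or on other cores.

Going by these compounds, whether a fluoro, a methoxy or an amine in place of the chloro would give a step of similar size remains open. On these data alone, with a single tested concentration, whether the effect would be stronger or weaker at any other concentration also remains open.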